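This account rests on a few compounds, and the source may have more. Where it says the series, first, only, none or still open, it means among the compounds named here.

Compound 1 `COc1ccccc1-c1cn(C[C@H](O)[C@H]2OC(=O)C(OCc3ccccc3)=C2OCc2ccccc2)nn1` is the starting point. In a functional assay on CFPAC-1 cells (Homo sapiens) for antiproliferative activity, read by MTT assay, with a stated time of 72 h (a higher number here means a weaker inhibitor, a lower number a stronger inhibitor), compound 1 gives > 100000 nM, which is a limit of the assay rather than a number. Compound 2 `O=C1O[C@H]([C@@H](O)Cn2cc(C3CC3)nn2)C(OCc2ccccc2)=C1OCc1ccccc1` carries a cyclopropyl in place of the 2-methoxyphenyl on an aromatic carbon, and in this assay compound 2 gives 47700 nM. For the measured compounds named here, the step of an at least 2.0-fold lower number from compound 1 to compound 2 (0.32 log units; beyond the scatter) is the only measured step here, and its size rests on (the limit of > 100000 nM in this assay, at which 1 of the 2 values shown sits). Compound 2 thus holds the only real number shown; the other value is a limit.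

Compound 3 `O=C1O[C@H]([C@@H](O)Cn2cc(CNS(=O)(=O)c3ccc(Cl)cc3)nn2)C(OCc2ccccc2)=C1OCc1ccccc1` is not yet measured. It differs from compound 2 by (((4-chlorophenyl)sulfonyl)amino)methyl in place of cyclopropyl on an aromatic carbon. Going by the values given here, only the step from compound 1 to compound 2 touches the same aromatic carbon, and it was at least modest; but that step traded one ring for a small ring, whereas here the small ring gives way to a far larger group. Among the compounds with values here, no measured step shows what such a group does at this position, so the direction is open. Compound 3 is therefore expected to give roughly 30000 nM in this assay, between 8000 nM and 150000 nM. This amounts to an expected step of a 1.6-fold lower number from compound 2 to compound 3 (0.20 log units; within the scatter), staying near the scatter.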

Compound 3, half-maximal inhibitory concentration: 38900 nM
For compound 3 the middle estimate is 1.3-fold (0.11 log units) below the measured one; the range from low to high includes it.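

Swapping cyclopropyl for the far larger (((4-chlorophenyl)sulfonyl)amino)methyl, with 12 heavy atoms against 3 and a hydrogen-bond donor and acceptors that cyclopropyl lacks, gives a 1.2-fold lower number from compound 2 to compound 3 (0.09 log units; within the scatter), so compound 2 and compound 3 cannot be told apart in this assay. This aromatic carbon therefore accepts a small ring and a much larger group with no measurable difference, and across these two compounds the number does not follow the size of the group. Replacing the 2-methoxyphenyl gives an at least 2.5-fold lower number from compound 1 to compound 3 (0.41 log units; beyond the scatter), making this the second group at this carbon, after cyclopropyl, to show a lower number than compound 1, and the size of that step rests on a limit rather than a real number: the limit of > 100000 nM in this assay, at which 1 of the 3 values shown sits.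

The compounds shown leave open which part of the new group matters, and a plain amine or a simple amide at this carbon would help to separate the sulfonyl and the 4-chlorophenyl from the rest. They also leave open whether a carboxylic acid or a longer carbon chain here would move the number beyond the scatter.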